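This account rests on a few compounds, and the source may have more. Where it says the series, first, only, none or still open, it means among the compounds named here.

Working notes on a set of triazole-linked coumarin ethers examined in a functional assay on HT-29 cells (Homo sapiens) for cytotoxicity, read by MTT assay, with a stated time of 24 h; a higher number here means a weaker inhibitor, a lower number a stronger inhibitor. Compound 1 `O=Cc1ccc(OCc2cn(CCCOc3ccc4ccc(=O)oc4c3)nn2)cc1` gives 100000 nM. Compound 2 `COc1cc(C=O)ccc1OCc1cn(CCCOc2ccc3ccc(=O)oc3c2)nn1` gives 65400 nM. Compound 2 differs from compound 1 by methoxy in place of hydrogen on an aromatic carbon, a step of a 1.5-fold lower number from compound 1 to compound 2 (0.18 log units; within the scatter). Compound 3 `NS(=O)(=O)c1ccc(C/N=C/c2ccccc2OCc2cn(CCCOc3ccc4ccc(=O)oc4c3)nn2)cc1` gives 14300 nM, the lowest number of the three; the difference between the core of compound 3 and the core of compound 1 is not broken down here. Compound 4 `COc1cccc(/C=N/Cc2ccc(S(N)(=O)=O)cc2)c1OCc1cn(CCCOc2ccc3ccc(=O)oc3c2)nn1` is still to be run in this assay; relative to compound 3 it carries methoxy in place of hydrogen on an aromatic carbon. This is the same kind of change as that seen between compound 1 and compound 2, though the surroundings are not identical: in compound 2 the methoxy sits meta to a formyl group, in compound 4 meta to a large group. Because a 1.5-fold lower number from compound 1 to compound 2 (0.18 log units; within the scatter) lay within the scatter, the step of a 1.3-fold lower number from compound 3 to compound 4 (0.11 log units; within the scatter) is expected to be similarly small. Compound 4 is accordingly estimated at 11000 nM, with 5000 nM and 25000 nM as the expected bounds.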

Compound 4, half-maximal inhibitory concentration: 52500 nM
Estimate against measurement, compound 4: 4.8-fold (0.68 log units) below; the whole stated range lies below it.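

Methoxy in place of hydrogen on an aromatic carbon gives a 3.7-fold higher number from compound 3 to compound 4 (0.56 log units; beyond the scatter) in this assay, and the step on the core of compound 1 does not carry over to the core of compound 3: the same change on two cores in this assay, a 1.5-fold lower number (0.18 log units; within the scatter) from compound 1 to compound 2 and a 3.7-fold higher number (0.56 log units; beyond the scatter) from compound 3 to compound 4, 5.6-fold (0.75 log units) apart, beyond the scatter of two such steps. Within this series, the outcome of this change therefore depends on the core, at least across these two pairs. Two pairs give no general rule, and they do not show which difference between the cores matters, since that difference is not broken down and the methoxy of compound 4 sits ortho to a large group and meta to a large group.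

The compounds shown leave open whether a hydroxyl or an ethoxy group in the same place would follow the methoxy step on either core. On these data alone, it also remains open whether the step on the core of compound 3 would persist with an amine in place of the imine.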